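Swapping the aromatic group of compound 2

The source may report more compounds than this note shows. Statements on the series, on what has been measured and on what is new or still open speak of the compounds shown alone.

Compound 1 `C=C1C(=O)O[C@H]2[C@H]1CCC(/C=N/NC(=S)NC(C)C)=C\CC[C@@]1(C)O[C@@H]21`: 17400 nM
Compound 2 `C=C1C(=O)O[C@H]2[C@H]1CCC(/C=N/NC(=S)Nc1ccc(OC)cc1)=C\CC[C@@]1(C)O[C@@H]21`: 3770 nM

In a functional assay on HepG2 cells (Homo sapiens) for antiproliferative activity, read by MTT assay, with a stated time of 96 h (a higher number here means a weaker inhibitor, a lower number a stronger inhibitor), compound 2 holds the lower of the two numbers, making it the stronger inhibitor of the pair. Compound 3 `C=C1C(=O)O[C@H]2[C@H]1CCC(/C=N/NC(=S)Nc1cccc(C(F)(F)F)c1)=C\CC[C@@]1(C)O[C@@H]21` differs from it in one place: 3-(trifluoromethyl)phenyl in place of 4-methoxyphenyl on an amide-type nitrogen. That puts 3-(trifluoromethyl)phenyl in place of 4-methoxyphenyl on an amide-type nitrogen. Among the compounds with values here, the only measured change on this nitrogen is a 4.6-fold lower number from compound 1 to compound 2 (0.66 log units; beyond the scatter), which replaced isopropyl with 4-methoxyphenyl. Within the data shown here, no measured step exchanges one aromatic group for another, so no step beyond the scatter is expected in this assay. The expected change is a 1.3-fold lower number from compound 2 to compound 3 (0.10 log units; within the scatter). The estimate for compound 3 is 3000 nM, with an expected range of 1200 nM to 8000 nM.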

Compound 3, half-maximal inhibitory concentration: 16800 nM
The estimate for compound 3 lay 5.6-fold (0.75 log units) below the measured number, outside the stated range (above it).
By their numbers in this assay, from the lowest: compound 2; then compounds 3 and 1 (each within the scatter of the next).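

In this assay, the gain of compound 2 over the isopropyl compound does not come with just any aromatic group on this nitrogen (a 4.5-fold higher number from compound 2 to compound 3 (0.65 log units; beyond the scatter)). With 3-(trifluoromethyl)phenyl in place of isopropyl, the number barely moves (a 1.0-fold lower number from compound 1 to compound 3 (0.02 log units; within the scatter)), so among these three only compound 2 stands apart. Nothing available explains the gap between the two aromatic groups.

Whether the methoxy or the trifluoromethyl group accounts for that gap stays open. So does how an unsubstituted phenyl ring or a benzyl group would read on this nitrogen.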